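This account rests on a few compounds, and the source may have more. Where it says the series, first, only, none or still open, it means among the compounds named here.

Values in a functional assay on brain (Rattus norvegicus, strain Wistar) for inhibition; on this read-out higher numbers stand for weaker inhibition and lower numbers for stronger inhibition:

- Compound 1 `Cc1[nH]c(=O)n(C)c1-c1ccccc1`: > 100000 nM, a limit of the assay
- Compound 2 `Cc1[nH]c(=O)n(C)c1-c1ccc(CC(C)C)cc1`: 7800 nM
- Compound 3 `Cc1[nH]c(=O)n(C)c1-c1ccc(C(C)(C)C)cc1`: 8400 nM

Compound 3 gives 8400 nM and stands level with compound 2, as the step between them lies within the scatter: a 1.1-fold higher number from compound 2 to compound 3 (0.03 log units; within the scatter). Both of these compounds differ sharply from compound 1, with large steps: an at least 12-fold lower number from compound 1 to compound 2 (1.10 log units; beyond the scatter) and an at least 11-fold lower number from compound 1 to compound 3 (1.07 log units; beyond the scatter). Both steps start from the limit of compound 1.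

Compound 4 `CCCCCOc1ccc(-c2c(C)[nH]c(=O)n2C)cc1` carries pentyloxy in place of tert-butyl on an aromatic carbon. The nearest guide is the exchange of isobutyl for tert-butyl, which left the number within the scatter: a 1.1-fold higher number from compound 2 to compound 3 (0.03 log units; within the scatter). The large steps from compound 1 concern adding a group in place of hydrogen, whereas compound 4 only exchanges one group for another. Among the measured compounds shown here, no measured compound carries pentyloxy, so the estimate remains an extrapolation. A small change is therefore expected, perhaps slightly towards a lower number and far smaller than the steps from compound 1. The expected step is a 1.9-fold lower number from compound 3 to compound 4 (0.27 log units; within the scatter). For compound 4 the estimated value is 4500 nM, with an expected range from 1200 nM to 16000 nM.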

Compound 4, half-maximal inhibitory concentration: 4500 nM
Compound 4: the middle estimate sits on the measured number at the digits printed; low and high end bracket the measured number.
By their numbers in this assay, from the lowest: compounds 4, 2 and 3 (each within the scatter of the next). At a limit, above all of these: compound 1.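

In this assay, the place on the six-membered aromatic ring now accepts a group that carries oxygen, and pentyloxy stands level with both hydrocarbon groups: a 1.9-fold lower number from compound 3 to compound 4 (0.27 log units; within the scatter), and a 1.7-fold lower number from compound 2 to compound 4 (0.24 log units; within the scatter). Branched isobutyl and tert-butyl had already shown that exchanging one hydrocarbon group for another leaves the number within the scatter; compound 4 extends this to a longer group with one hydrogen-bond acceptor, so neither that acceptor nor the two extra heavy atoms produce a step that can be read beyond the scatter here. The contrast with hydrogen at this place remains large, an at least 22-fold lower number from compound 1 to compound 4 (1.34 log units; beyond the scatter), and this size is only a bound, since the step starts from compound 1, which gives: the limit of > 100000 nM in this assay, at which 1 of the 4 values shown sits.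

Pentyloxy differs from the earlier groups in both chain length and oxygen, so the effect of each cannot be separated; a plain hexyl chain or a short methoxy group would help divide them. From the compounds shown here alone, it also remains open whether the number stays level with a much longer chain, or with an amine or a carboxylic acid at the same place.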